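This account rests on a few compounds, and the source may have more. Where it says the series, first, only, none or still open, it means among the compounds named here.

Compound 1 `COc1cccc(OCC(=O)Nc2cccc(NC(=O)c3ccc(N(C)C)cc3)c2)c1` gives a limit in an assay on isolated protein for inhibition of Rho-associated protein kinase 1 (Homo sapiens), read by scintillation counting, radiometric assay and 33P incorporation, with a stated time of 40 min, in the presence of a further agent that is not named here; a lower number here means a stronger inhibitor, a higher number a weaker inhibitor: > 10000 nM. Compound 2 `COc1cc(OCC(=O)Nc2cccc(NC(=O)c3ccc(N(C)C)cc3)c2)ccc1C=O` gives 3740 nM. Compound 3 `N#Cc1ccc(C(=O)Nc2cccc(NC(=O)COc3ccc4c(=O)ccoc4c3)c2)cc1` gives 123 nM.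

Among the two numbers shown, compound 3 gives the lowest, and compound 2 gives a higher number, a gap told as beyond the scatter; compound 1 shows only a limit (the limit of > 10000 nM in this assay, at which 1 of the 3 values shown sits). Compound 4 `O=C(COc1ccc2c(=O)ccoc2c1)Nc1cccc(NC(=O)c2cnc(C(F)(F)F)s2)c1` differs from compound 3 in one place: 2-(trifluoromethyl)-1,3-thiazol-5-yl in place of 4-cyanophenyl on a carbonyl carbon. Within the data shown here, the only measured step, an at least 2.6-fold lower number from compound 1 to compound 2 (0.42 log units; beyond the scatter), concerns a formyl added on an aromatic carbon elsewhere in the shared core and so does not bear on an exchange of the aryl on the carbonyl. Without a relevant precedent, a modest step is expected in this assay, a 2.0-fold higher number from compound 3 to compound 4 (0.31 log units; beyond the scatter), and compound 4 is estimated at 250 nM, between 70 nM and 900 nM.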

Compound 4, half-maximal inhibitory concentration: 160 nM
The estimate for compound 4 lay 1.6-fold (0.19 log units) above the measured number, within the range that was stated.
By their numbers in this assay, from the lowest: compounds 3 and 4 (each within the scatter of the next); then compound 2. At a limit, above all of these: compound 1.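

In this assay, 2-(trifluoromethyl)-1,3-thiazol-5-yl in place of 4-cyanophenyl on the carbonyl carbon gives a 1.3-fold higher number from compound 3 to compound 4 (0.11 log units; within the scatter). This position therefore holds a five-membered aromatic ring with 2 hetero atoms as well as a six-membered aromatic ring of carbon only, without a change that can be told from the scatter. Nothing measured here accounts for this. The compounds shown leave open how a non-aromatic group on this carbonyl carbon, such as a piperidine ring or a simple alkyl chain, would read in this assay. They also leave open what an amine or a carboxylic acid on the aromatic ring would do.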